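The source may report more compounds than this note shows. Statements on the series, on what has been measured and on what is new or still open speak of the compounds shown alone.

Compound 1, `Cc1ccc(S(=O)(=O)N[C@@H](CC(=O)NC(C)(C)C)C(=O)NCCNC(=O)Nc2ccccc2)cc1`, gives in an ADME assay on Karpas-1106P cells (Homo sapiens) for cytotoxicity (a higher number here means that more compound is needed for the effect, a lower number that less compound is needed), the limit > 11100 nM, not a number.
Compound 2, `Cc1ccc(S(=O)(=O)N[C@@H](CC(=O)NC(C)(C)C)C(=O)NCCNC(=O)c2ccccc2F)cc1`, gives in this assay the limit > 11100 nM.
Compound 3, `Cc1ccc(S(=O)(=O)N[C@@H](CC(=O)NC(C)(C)C)C(=O)NCCNC(=O)c2cc(Cl)ccc2Cl)cc1`, gives in this assay the limit > 11100 nM.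

Compound 2 stands at the limit of > 11100 nM in this assay, at which 3 of the 3 values shown sit. The measured steps, a step that the two limits leave unreadable from compound 1 to compound 2, a step that the two limits leave unreadable from compound 1 to compound 3 and a step that the two limits leave unreadable from compound 2 to compound 3, all lie between limits and tell nothing of size or direction. The change to compound 4, `Cc1ccc(S(=O)(=O)N[C@@H](CC(=O)NC(C)(C)C)C(=O)NCCNC(=O)c2ccccn2)cc1`, is pyridin-2-yl in place of 2-fluorophenyl on a carbonyl carbon. Within the data shown here, nothing among the measured steps is readable, so the expectation is only that compound 4 also stays at the limit, with a step that the limit leaves unreadable from compound 2 to compound 4 expected in this assay. For compound 4 the estimate in this assay is 15000 nM, expected between 5000 nM and 50000 nM.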

Compound 4, half-maximal effective concentration: > 11100 nM
Compound 4 ended at the assay's limit; the forecaster's own chance of this, stated with the estimate: 85%; the middle value does not contradict the limit.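

Compound 4 gives the limit > 11100 nM in this assay, and its steps from compound 1, compound 2 and compound 3 cannot be read. The compounds shown leave open whether any change on the carbonyl carbon alters the half-maximal effective concentration.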